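The source may report more compounds than this note shows. Statements on the series, on what has been measured and on what is new or still open speak of the compounds shown alone.

Among the compounds with values here, in an ADME assay on MRC5 cells (Homo sapiens) for antiproliferative activity, read by MTT assay (a higher number here means a weaker inhibitor, a lower number a stronger inhibitor), compound 2 `C/C(=N\NC(=O)c1ccc(Br)cc1)c1cnccn1` gives 2940 nM, the only exact number so far. Compound 1 `C/C(=N\NC(=O)c1ccc(N)cc1)c1cnccn1` gives > 80000 nM in this assay, which is a limit and not a number. Compound 3 `C/C(=N\NC(=O)c1ccccc1)c1cnccn1` differs from compound 2 by hydrogen in place of bromo on an aromatic carbon. Within the data shown here, one measured step bears on this change, the large at least 27-fold lower number from compound 1 to compound 2 (1.43 log units; beyond the scatter), which put bromo in place of amino. Compound 3 carries neither group, so only part of that large step is expected to be lost. The expected change is a 4.1-fold higher number from compound 2 to compound 3 (0.61 log units; beyond the scatter), towards a higher number and weaker inhibition. For compound 3 the estimated value is 12000 nM, within a range of 3500 nM to 45000 nM.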

Compound 3, half-maximal inhibitory concentration: 7040 nM
Estimate against measurement, compound 3: 1.7-fold (0.23 log units) above, and the stated range covers the measured number.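

Compound 3 supplies the plain reference for this position: in this assay, hydrogen in place of bromo gives a 2.4-fold higher number from compound 2 to compound 3 (0.38 log units; beyond the scatter) and so a real but modest loss. Hydrogen in place of amino is the larger change, with an at least 11-fold lower number from compound 1 to compound 3 (1.05 log units; beyond the scatter) as its result, so most of the earlier gap lies on the amino side. The second step has no fixed size because compound 1 stands at a limit and not at a number: the limit of > 80000 nM in this assay, at which 1 of the 3 values shown sits.

The compounds shown leave open whether chloro, methoxy or a carboxylic acid at this place would behave like bromo, hydrogen or amino.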